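Acyl variation on the ring nitrogen: compound 3

The source may hold more compounds than are shown below. What is called first, only, known or untested is meant among the compounds shown, and "the series" means these compounds.

Measured so far:
compound 1 `Cc1nc(S(C)(=O)=O)ccc1Oc1ncnc(OC2CCN(C(=S)OC3(C)CC3)CC2)c1F` gives 49%
compound 2 `Cc1nc(S(C)(=O)=O)ccc1Oc1ncnc(OC2CCN(C(=O)C(F)(F)F)CC2)c1F` gives 76%

Both compounds share one core and differ only in the group on the amine nitrogen in the ring. For the measured compounds named here, in a functional assay on isolated protein for inhibition of Glucose-dependent insulinotropic receptor (Rattus norvegicus), read by HTRF and cAMP accumulation (a higher number here means a larger maximal response, a lower number a smaller maximal response), compound 2 gives the higher of the two numbers; the single measured step, a number 27 percentage points higher from compound 1 to compound 2 (beyond the scatter), separates it from compound 1.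

Compound 3 `Cc1nc(S(C)(=O)=O)ccc1Oc1ncnc(OC2CCN(C(=O)C3(F)CCC3)CC2)c1F` keeps the carbonyl of compound 2 and changes only the group on the carbonyl carbon: a group of 5 heavy atoms (4 carbon, 1 fluorine; one four-membered non-aromatic ring of carbon only) in place of a group of 4 heavy atoms (1 carbon, 3 fluorine; no ring), on a carbonyl carbon.

Going by the values given here, no measured step touches the same place. Among the compounds with values here, the one step known, from compound 1 to compound 2, exchanged the whole substituent on the ring nitrogen and was modest; the change to compound 3 is smaller in scope, so a step no larger than that one, in either direction or within the scatter, is expected, a number 11 percentage points lower from compound 2 to compound 3 (beyond the scatter). For compound 3 the expected value in this assay is 65%, with a range from 45% to 85%.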

Compound 3, largest response reached (reported as efficacy), in percent of the reference or control that the assay uses: 91%
The estimate for compound 3 lay 26 percentage points below the measured number, and the stated range ends below it.
By their numbers in this assay, from the lowest: compound 1; then compound 2; then compound 3.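

Working notes: in this assay, the group on a carbonyl carbon alone moves the maximal response, with a number 15 percentage points higher from compound 2 to compound 3 (beyond the scatter) when the fluorinated four-membered ring group replaces trifluoromethyl, so trifluoromethyl does not mark the top of the series at this position. Across the whole substituent on the amine nitrogen in the ring, a number 42 percentage points higher from compound 1 to compound 3 (beyond the scatter) is the widest step among the three compounds, though that step changes more than one feature of the substituent and cannot assign the rise to any one of them. Nothing measured here bears on the reason for the rise.

The compounds shown leave open what the ring fluorine contributes, since no pair differs by that atom alone. Also open, on these data alone, is how an amine or a longer alkyl chain on the carbonyl carbon would read in this assay.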